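The source may report more compounds than this note shows. Statements on the series, on what has been measured and on what is new or still open speak of the compounds shown alone.

Measured compounds:
Compound 1, `C#CCOCC(N)C(=O)NCc1ccccc1`: in a functional assay on the whole organism (strain NMRI) for inhibition, with Mus musculus as the target, in the formalin test, with a stated time of 30 min (on this read-out lower numbers stand for an effect already at smaller amounts and higher numbers for an effect only at larger amounts of compound), compound 1 gives 74 mg/kg.
Compound 2, `C=CCOCC(N)C(=O)NCc1ccccc1`: compound 2 gives 75 mg/kg.
Compound 3, `CSCC[C@@H](N)C(=O)NCc1ccccc1`: compound 3 gives only a limit of the assay, > 76 mg/kg.

Compound 3 thus stands apart from the other two not by a number but by a limit; of the three values, one sits at that limit (the limit of > 76 mg/kg in this assay, at which 1 of the 3 values shown sits). For the measured compounds named here, compounds 1 and 2 lie close together, and the only step measured between neighbours, a 1.0-fold higher number from compound 1 to compound 2 (0.01 log units; within the scatter), concerns the ether chain rather than the carbon that carries the amine, so it says little about the change now in question.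

The step from compound 3 to the unmeasured compound 4, `CC(C)(C)[C@@H](N)C(=O)NCc1ccccc1`, is a change of the side chain on that carbon: tert-butyl in place of 2-(methylsulfanyl)ethyl on a saturated chain carbon bound to an amine nitrogen and a carbonyl carbon. Going by the values given here, no measured step touches this position, so the expectation rests on where compound 3 itself stands, at a limit. Compound 4 is expected to remain at or near that limit, with a step that the limit leaves unreadable from compound 3 to compound 4 that is estimated to stay within the scatter. The estimate for compound 4 in this assay is 100 mg/kg, with a range from 50 mg/kg to 300 mg/kg, and a substantial chance that only a limit is reported.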

Compound 4, dose for half-maximal effect: > 22 mg/kg
Compound 4 gave a limit, no number; the forecaster's own chance of this, stated with the estimate: 60%; the middle value is on the limit's open side.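

In this assay compound 4 gives only a limit, > 22 mg/kg. Compound 3 likewise gives only a limit, > 76 mg/kg. With a limit on both sides, the step between compound 3 and compound 4 cannot be read. The compounds shown leave open how tert-butyl and 2-(methylsulfanyl)ethyl compare on a saturated chain carbon bound to an amine nitrogen and a carbonyl carbon.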